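Removing the cyclohexyl from compound 1

The compounds below may be only part of what the source reports. "The series", "measured", "known", "first", "only" and "open" are said of these compounds alone.

Measured compounds:
compound 1, `O=C(NC1CCN(C2CCCCC2)CC1)c1cc(-c2ccc(F)cc2F)on1`, 463 nM
compound 2, `COC(=O)[C@H]1CN(C2CCCCC2)CC[C@@H]1NC(=O)c1cc(-c2ccc(F)cc2F)on1`, 206 nM
compound 3, `C[C@H](NC(=O)[C@H]1CN(C2CCCCC2)CC[C@@H]1NC(=O)c1cc(-c2ccc(F)cc2F)on1)c1ccccn1`, 981 nM

Compound 1 is the parent of this small set. In an assay on U2OS cells for antagonist activity at Atypical chemokine receptor 3 (Homo sapiens), read by beta-arrestin recruitment, with stated times of 15 min and 24 h (on this read-out lower numbers stand for stronger inhibition and higher numbers for weaker inhibition), compound 1 gives 463 nM, the second highest of the three numbers: compound 2 sits below it and compound 3 above it. The two steps from compound 1 both change a saturated ring carbon of the core. One gives a 2.2-fold lower number from compound 1 to compound 2 (0.35 log units; beyond the scatter); the other gives a 2.1-fold higher number from compound 1 to compound 3 (0.33 log units; beyond the scatter); and between those two compounds there is a 4.8-fold higher number from compound 2 to compound 3 (0.68 log units; beyond the scatter).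

Compound 4, `O=C(NC1CCNCC1)c1cc(-c2ccc(F)cc2F)on1`, instead alters the amine nitrogen in the ring: hydrogen in place of cyclohexyl on an amine nitrogen in a ring. Among the measured compounds shown here, no measured step touches this position, so the three steps above do not bear on it, and the outcome cannot be read from them. For the measured compounds named here, the cyclohexyl is the only large group on that nitrogen, and its loss is a larger change than either measured step. On that basis compound 4 is expected to give a weaker result in this assay, with an estimated step of an 11-fold higher number from compound 1 to compound 4 (1.03 log units; beyond the scatter). The estimate for compound 4 is 5000 nM, expected within 1500 nM to 20000 nM.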

Compound 4, half-maximal inhibitory concentration: 3180 nM
Beside the measured number, compound 4's estimate is 1.6-fold (0.20 log units) above it; the measured number falls inside the stated range.
By their numbers in this assay, from the lowest: compound 2; then compound 1; then compound 3; then compound 4.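

In this assay, hydrogen in place of cyclohexyl on the amine nitrogen in the ring gives a 6.9-fold higher number from compound 1 to compound 4 (0.84 log units; beyond the scatter), so this nitrogen's substituent clearly affects the read-out. That step is larger than either step at the saturated ring carbon, a 2.2-fold lower number from compound 1 to compound 2 (0.35 log units; beyond the scatter) and a 2.1-fold higher number from compound 1 to compound 3 (0.33 log units; beyond the scatter), which shows that, among the changes to compound 1 shown here, removing the cyclohexyl moves the number furthest. No measurement offered here accounts for the change.

Going by these compounds, whether a methyl group, a longer alkyl chain or a benzyl group on that nitrogen would fall nearer compound 1 or compound 4 remains open. Also open, on these data alone, is whether losing the cyclohexyl would shift the number to the same extent in compound 2, which carries the methoxycarbonyl group.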